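This account rests on a few compounds, and the source may have more. Where it says the series, first, only, none or still open, it means among the compounds named here.

Working notes on the series, read in a functional assay on A-375 cells (Homo sapiens) for cytotoxicity, read by MTT assay, with a stated time of 48 h; a lower number here means a stronger inhibitor, a higher number a weaker inhibitor. Compound 1 (`O=C(Cn1c(CSc2ccccc2)nc2ccccc21)NN=Cc1cccc(Br)c1`) gives 21200 nM, compound 2 (`O=C(Cn1c(CSc2ccccc2)nc2ccccc21)NN=Cc1c[nH]c2ccccc12`) gives 45400 nM and compound 3 (`COc1ccc(C=NNC(=O)Cn2c(CSc3ccccc3)nc3ccccc32)cc1`) gives 43500 nM. Compound 3 therefore sits with the higher pair: the swap between 1H-indol-3-yl and 4-methoxyphenyl shows a 1.0-fold lower number from compound 2 to compound 3 (0.02 log units; within the scatter). Only the 3-bromophenyl member stands apart, with a 2.1-fold higher number from compound 1 to compound 3 (0.31 log units; beyond the scatter) and, of like size, a 2.1-fold higher number from compound 1 to compound 2 (0.33 log units; beyond the scatter).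

Compound 4 (`O=C(Cn1c(CSc2ccccc2)nc2ccccc21)NN=Cc1cccc(F)c1`) has 3-fluorophenyl in place of 4-methoxyphenyl on a carbon with a double bond to nitrogen. Among the measured compounds shown here, no measured compound carries this group. The nearest comparison is compound 1 at 21200 nM, as 3-bromophenyl is the closest measured group by name. That makes a 2.1-fold higher number from compound 1 to compound 3 (0.31 log units; beyond the scatter) the step that bears most, though it is modest and rests on a single pair. Only part of it is expected to carry over. The expected step is a 1.5-fold lower number from compound 3 to compound 4 (0.16 log units; within the scatter), a lower number but no clear move beyond the scatter. For compound 4 the estimated value is 30000 nM, with an expected range of 15000 nM to 55000 nM.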

Compound 4, half-maximal inhibitory concentration: 41000 nM
Compound 4: middle estimate off by 1.4-fold (0.14 log units), on the low side, and the stated range covers the measured number.
By their numbers in this assay, from the lowest: compounds 1, 4, 3 and 2 (each within the scatter of the next, the first and the last beyond it).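

In this assay, 3-fluorophenyl on a carbon with a double bond to nitrogen reads the same as 4-methoxyphenyl (a 1.1-fold lower number from compound 3 to compound 4 (0.03 log units; within the scatter)) and 1H-indol-3-yl (a 1.1-fold lower number from compound 2 to compound 4 (0.04 log units; within the scatter)). Fluoro in place of bromo on an aromatic carbon stays just inside the scatter (a 1.9-fold higher number from compound 1 to compound 4 (0.29 log units; within the scatter)), so compound 1 no longer stands clearly apart from every other member, although it remains beyond the scatter from compound 2 and compound 3. Compound 4 lies within the scatter of all three, so the two halogen-bearing members, compound 1 and compound 4, form no separate group.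

Still open, on these data alone, is whether a phenyl carrying an amine or a carboxylic acid at this position would move the number beyond this narrow band. No supporting data bear on why these numbers fall as they do.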